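Methoxy on the aryl ether: three limits and a fourth

A few compounds are considered here, and "the series" means these few. Any claim that something is new, unique, unknown or untested is made for them only; others in the source may bear on it.

Measured compounds:
compound 1 `C=C(C)[C@@H]1CC=C(Cn2cc(COc3ccc(C4NC(=O)NC(C)=C4C(=O)OCC)cc3)nn2)CC1` — > 100000 nM
compound 2 `C=C(C)[C@@H]1CC=C(Cn2cc(COc3ccc(C4NC(=O)NC(C)=C4C(=O)OCC)cc3OC)nn2)CC1` — > 100000 nM
compound 3 `C=C(C)[C@@H]1CC=C(Cn2cc(COc3ccc(C4NC(=O)NC5=C4C(=O)CC(C)(C)C5)cc3)nn2)CC1` — > 100000 nM

In a functional assay on NCI-H460 cells (Homo sapiens) for inhibition, read by sulforhodamine B assay, with a stated time of 48 h (on this read-out lower numbers stand for stronger inhibition of growth and higher numbers for weaker inhibition of growth), compound 1 gives > 100000 nM, which is a limit of the assay and not a number. Compound 2 gives > 100000 nM, again a limit. Compound 3 gives > 100000 nM, also a limit. From compound 1 to compound 2 the change is methoxy in place of hydrogen on an aromatic carbon, and the step is a step that the two limits leave unreadable from compound 1 to compound 2. The difference between the core of compound 1 and the core of compound 3 is not broken down here. Compound 4 `C=C(C)[C@@H]1CC=C(Cn2cc(COc3ccc(C4NC(=O)NC5=C4C(=O)CC(C)(C)C5)cc3OC)nn2)CC1` carries the same change on the core of compound 3, namely (methoxy in place of hydrogen on an aromatic carbon). Among the measured compounds shown here, the only evidence bearing on these steps is the limit of > 100000 nM in this assay, at which 3 of the 3 values shown sit.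

The estimated step of a number no higher from compound 3 to compound 4 (the limit leaves the size open) is expected to be of the same unreadable kind because a step that the two limits leave unreadable from compound 1 to compound 2 gave nothing readable on the core of compound 1. For the measured compounds named here, with every value so far sitting at a limit, compound 4 is expected to give 100000 nM in this assay, most likely reported again only as a limit.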

Compound 4, concentration for total growth inhibition: > 100000 nM
Compound 4: a limit, no number; the forecaster's own chance of this, stated with the estimate: 85%; the middle value sits exactly at the limit.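

In this assay compound 4 gives > 100000 nM, a limit and not a number. The step from compound 3 to compound 4 cannot be read, and neither can the step from compound 1 to compound 2. The compounds shown leave open how large the effect of methoxy in place of hydrogen on an aromatic carbon is on either core, and in which direction it runs: the limit of > 100000 nM in this assay, at which 4 of the 4 values shown sit.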